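The source may report more compounds than this note shows. Statements on the series, on what has been measured and on what is new or still open speak of the compounds shown alone.

Measured so far:
compound 1, `CO[C@H]1C(=O)N2C(C(=O)C(C)(C)C)=C(C)[C@@H](OC=O)S(=O)(=O)C12`: < 0.5 h
compound 2, `CO[C@H]1C(=O)N2C(C(=O)C(C)(C)C)=C(C)[C@@H](OC(=O)c3ccccc3)S(=O)(=O)C12`: 24 h

Compound 2, `CO[C@H]1C(=O)N2C(C(=O)C(C)(C)C)=C(C)[C@@H](OC(=O)c3ccccc3)S(=O)(=O)C12`, holds the only number shown in a physicochemical assay, at pH 7.4 (on this read-out higher numbers stand for a longer-lived compound and lower numbers for a shorter-lived compound), namely 24 h. In this assay compound 1, `CO[C@H]1C(=O)N2C(C(=O)C(C)(C)C)=C(C)[C@@H](OC=O)S(=O)(=O)C12`, gives only a limit, < 0.5 h. Among the measured compounds shown here, the one measured step, an at least 48-fold higher number from compound 1 to compound 2 (1.68 log units; beyond the scatter), is the sole guide available; its size rests on compound 1 sitting at the limit of < 0.5 h in this assay, at which 1 of the 2 values shown sits.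

Compound 3, `CO[C@H]1C(=O)N2C(C(=O)C(C)(C)C)=C(C)[C@@H](Sc3ccccn3)S(=O)(=O)C12`, differs from compound 2 by (pyridin-2-yl)sulfanyl in place of benzoyloxy on a saturated ring carbon. That step removes the whole carbonyl-bearing group rather than altering what sits on its carbonyl carbon, so the measured step bears on it only loosely. Compound 3 is therefore expected to stay near compound 2, with a step of a 1.3-fold higher number from compound 2 to compound 3 (0.10 log units; within the scatter) in this assay that need not exceed the scatter. Compound 3 is estimated at 30 h, within 5 h to 150 h.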

Compound 3, half-life: 24 h
Compound 3: middle estimate off by 1.3-fold (0.10 log units), on the high side; measured number inside the range.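

In this assay, the exchange at this saturated ring carbon, next to the ring sulfur, gives no change at the digits printed from compound 2 to compound 3 (within the scatter), so a long half-life does not depend on the benzoyloxy group or its carbonyl. Replacing formyloxy with the same (pyridin-2-yl)sulfanyl group gives an at least 48-fold higher number from compound 1 to compound 3 (1.68 log units; beyond the scatter), so two different groups bearing a six-membered aromatic ring now stand apart from formyloxy, which has none. The size of this second step is bounded rather than exact, since it rests on a limit for compound 1: the limit of < 0.5 h in this assay, at which 1 of the 3 values shown sits.

Going by these compounds, it remains open whether an aromatic ring on this carbon is required, since an acetoxy or methylsulfanyl group, which lacks one, could show otherwise. On these data alone, how an amine or a carboxylic acid at this place would behave also remains unknown.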